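Sulfonyl aryl exchange carried onto a second benzyl core

This account rests on a few compounds, and the source may have more. Where it says the series, first, only, none or still open, it means among the compounds named here.

Measured so far in a functional assay on RS4-11 cells (Homo sapiens) for inhibition, read by CCK-8 assay, with a stated time of 48 h, tested at 20 uM; on this read-out lower numbers stand for less inhibition of growth and higher numbers for more inhibition of growth at the one concentration tested:
- compound 1 `COc1ccc(Cc2nnc(NC(=O)/C(C#N)=C/c3ccccc3OS(=O)(=O)c3ccccc3[N+](=O)[O-])s2)cc1`: compound 1 gives 68%
- compound 2 `COc1ccc(Cc2nnc(NC(=O)/C(C#N)=C/c3ccccc3OS(=O)(=O)c3ccc(F)cc3)s2)cc1`: compound 2 gives 80%
- compound 3 `N#C/C(=C\c1ccccc1OS(=O)(=O)c1ccccc1[N+](=O)[O-])C(=O)Nc1nnc(Cc2cccc(F)c2)s1`: compound 3 gives 68%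

Compound 4 `N#C/C(=C\c1ccccc1OS(=O)(=O)c1ccc(F)cc1)C(=O)Nc1nnc(Cc2cccc(F)c2)s1` is not yet measured. It differs from compound 3 by 4-fluorophenyl in place of 2-nitrophenyl on a sulfonyl sulfur. The same change has been made once before, from compound 1 to compound 2, as 4-fluorophenyl in place of 2-nitrophenyl on a sulfonyl sulfur; there it gave a number 12 percentage points higher from compound 1 to compound 2 (beyond the scatter). The two cores on which this change is made differ by 3-fluorophenyl in place of 4-methoxyphenyl on a saturated chain carbon bound to an aromatic carbon, a difference that gave no change at the digits printed from compound 1 to compound 3 (within the scatter). The place of the exchange is the same word for word in both pairs, so the change is the same, only carried onto the other core.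

Expectation for compound 4 in this assay: a step of about a number 10 percentage points higher from compound 3 to compound 4 (within the scatter) is expected, of the same size as the earlier one, because a number 12 percentage points higher from compound 1 to compound 2 (beyond the scatter) is the only precedent and the core difference, as no change at the digits printed from compound 1 to compound 3 (within the scatter) shows, did not move the read-out. A single precedent leaves the size uncertain, so the range is kept wide. Compound 4 is estimated at 78%, between 66% and 90%.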

Compound 4, percent growth inhibition at one concentration: 72%
The estimate for compound 4 lay 6 percentage points above the measured number; low and high end bracket the measured number.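

In this assay, 4-fluorophenyl in place of 2-nitrophenyl on the sulfonyl sulfur gives a number 4 percentage points higher from compound 3 to compound 4 (within the scatter), and this step does not differ from its earlier counterpart beyond the scatter: the same change on two cores in this assay, a number 12 percentage points higher (beyond the scatter) from compound 1 to compound 2 and a number 4 percentage points higher (within the scatter) from compound 3 to compound 4, 8 percentage points apart, within the scatter of two such steps
With the 4-fluorophenyl sulfonyl group in place, 3-fluorophenyl in place of 4-methoxyphenyl on the saturated chain carbon gives a number 8 percentage points lower from compound 2 to compound 4 (within the scatter), which also agrees with the step seen earlier: the same change on two cores in this assay, no change at the digits printed (within the scatter) from compound 1 to compound 3 and a number 8 percentage points lower (within the scatter) from compound 2 to compound 4, 8 percentage points apart, within the scatter of two such steps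
Within the data shown here, these results fit a change that carries from one core to the other, but they do not establish an equal gain on both cores: there are only two pairs, each read at a single concentration, and the step on the second core cannot itself be told from the scatter.

Still open, on these data alone, is whether an amine or a carboxylic acid on the sulfonyl aryl ring, or a longer alkyl chain in place of that ring, would carry across the two cores in the same way. Also open, as far as these compounds go, is whether these small steps would persist across a range of concentrations.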